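Compound 4 and a step away from hydroxymethyl

This account rests on a few compounds, and the source may have more. Where it says the series, first, only, none or still open, it means among the compounds named here.

Compound 1 `CS(=O)(=O)c1ccc(-c2nc3ccc(Cl)cc3nc2-c2ccc(Cl)cc2)cc1` gives 2000 nM
Compound 2 `COc1ccc2nc(NCCO)c(S(C)(=O)=O)nc2c1` gives 39800 nM
Compound 3 `CCCCNc1nc2ccccc2nc1S(C)(=O)=O` gives 12600 nM

All three values come from an ADME assay on HepG2 cells (Homo sapiens) for cytotoxicity, read by CellTiter-Glo, with a stated time of 48 h (a lower number here means that less compound is tolerated, a higher number that more compound is tolerated), and compound 2 stands highest among them. The steps down to compound 3 and to compound 1 both lie beyond the usual scatter, with compound 1 the furthest away.

Compound 4 `COc1ccc2nc(NCC(C)C)c(S(C)(=O)=O)nc2c1` has not yet been measured. It keeps the core of compound 2 and differs only in the chain: isopropyl in place of hydroxymethyl on a saturated chain carbon bound to a nitrogen on an aromatic ring.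

For the measured compounds named here, no two measured compounds differ in one place, so the data hold no direct precedent for this change. The nearest guide is compound 3 (12600 nM), whose chain also has no hydroxymethyl, although its core differs from that of compound 2. On that slim basis, a moderate move toward a lower number is expected, probably beyond the scatter, though a smaller one remains possible. The expected step is a 2.5-fold lower number from compound 2 to compound 4 (0.40 log units; beyond the scatter) in this assay on this estimate. For compound 4 the estimated value is 16000 nM (expected range 6000 nM to 40000 nM).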

Compound 4, half-maximal cytotoxic concentration: 12600 nM
The estimate for compound 4 lay 1.3-fold (0.10 log units) above the measured number, within the range that was stated.
By their numbers in this assay, from the lowest: compound 1; then compounds 3 and 4 (each within the scatter of the next); then compound 2.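

In this assay, for the compounds shown here, isopropyl in place of hydroxymethyl on a saturated chain carbon bound to a nitrogen on an aromatic ring gives a 3.2-fold lower number from compound 2 to compound 4 (0.50 log units; beyond the scatter), the first comparison in this set in which only one place differs. It shows that this end of the chain is not neutral: the same change, read one bond further out as 2-hydroxyethyl to isobutyl, moves the number beyond the scatter, although the step is modest and compound 4 still gives 12600 nM. The group that leaves carries a hydrogen-bond donor and a hydrogen-bond acceptor and the group that enters carries neither, but no measurement in hand accounts for the step.

Going by these compounds alone, the single step cannot separate the loss of the oxygen from the gain of the branched carbons, a question that a methoxy group or an unbranched propyl in the same place would address. From the compounds shown here alone, it also remains open how an amine, a carboxylic acid or a longer chain would read at this position, and whether the step would hold on a different core.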